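Indolyl in Place of Bromophenyl: Expected Cell Toxicity

The source may hold more compounds than are shown below. What is called first, only, known or untested is meant among the compounds shown, and "the series" means these compounds.

Three thiourea compounds have been measured in an ADME assay on Huh-7 cells (Homo sapiens) for cytotoxicity; on this read-out lower numbers stand for higher toxicity in this test and higher numbers for lower toxicity in this test. Compound 1 `NC(=S)Nc1cccc(OCCCCCNC(=S)Nc2cccc3ccccc23)c1` reaches only the assay limit of > 50000 nM, so no number is known for it. Compound 2 `NC(=S)Nc1cccc(OCCCCCCCNC(=S)Nc2cc(Cl)cc(Cl)c2)c1` gives 20000 nM. Compound 3 `NC(=S)Nc1cccc(OCCCCCCCCNC(=S)Nc2ccc(Br)cc2)c1` gives 18000 nM, the lower of the two numbers, though the gap to compound 2 lies within the scatter. Compound 4 `NC(=S)Nc1cccc(OCCCCCCCCNC(=S)Nc2ccc3[nH]ccc3c2)c1` has not yet been measured; it differs from compound 3 in one place: 1H-indol-5-yl in place of 4-bromophenyl on an amide-type nitrogen. For the measured compounds named here, no measured pair shows the effect of such a change, so the expectation rests on compound 3 at 18000 nM, with a small rise in the number expected, not clearly beyond the scatter. The estimate for compound 4 in this assay is 25000 nM, between 10000 nM and 60000 nM, an expected step of a 1.4-fold higher number from compound 3 to compound 4 (0.14 log units; within the scatter).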

Compound 4, half-maximal cytotoxic concentration: 18000 nM
Beside the measured number, compound 4's estimate is 1.4-fold (0.14 log units) above it; measured number inside the range.
By their numbers in this assay, from the lowest: compounds 3, 4 and 2 (each within the scatter of the next). At a limit, above all of these: compound 1.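

For the compounds shown here, this is the first pair of compounds that reads this position directly: with 1H-indol-5-yl in place of 4-bromophenyl on an amide-type nitrogen, this assay shows no change at the digits printed from compound 3 to compound 4 (within the scatter). In this single pair, a larger group with a hydrogen-bond donor leaves the read-out where it was. Nothing in the data shown explains this result. On these data alone, whether a group carrying an amine or a carboxylic acid would read the same on this nitrogen stays open. As far as these compounds go, the effect of a longer chain also stays open.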